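Swapping the aryl group for benzyl on a shared quinoline-free core

The source may report more compounds than this note shows. Statements on the series, on what has been measured and on what is new or still open speak of the compounds shown alone.

The study centres on compound 1 `FC(F)(F)c1ccc(-c2ccc3c(NCCCNCc4ccco4)ccnc3c2)cc1`, examined in a physicochemical assay for acid dissociation. In this assay compound 1 gives 9.47. Two companions carry the same chain and differ elsewhere: compound 2 `CCC(CC)c1ccc2c(NCCCNCc3cc(F)ccc3OC)ccnc2c1`, which in this assay gives 9.47, and compound 3 `FC(F)(F)c1cc(-c2ccc3c(NCCCNCc4ccco4)ccnc3c2)cc(C(F)(F)F)c1`, which in this assay gives 9.47. At the digits reported, compound 1 stands level with compound 2 and with compound 3; none of these pairs is separated by more than the usual scatter, so no order among the three can be read from them.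

The next compound, compound 4 `c1ccc(Cc2ccc3c(NCCCNCc4ccco4)ccnc3c2)cc1`, has not yet been measured. Its relation to compound 1 is a single replacement (benzyl in place of 4-(trifluoromethyl)phenyl on an aromatic carbon). Since compounds 1, 2 and 3, which carry different groups at or around this part of the core, all return the same number in this assay, the expected step from compound 1 to compound 4 is none beyond the scatter, in either direction. On that basis compound 4 is expected to give 9.47 in this assay, with a range from 9.15 to 9.8, and the estimated step of no change at the digits printed from compound 1 to compound 4 (within the scatter) is essentially nil.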

Compound 4, acid dissociation constant: 9.47
The estimate for compound 4 equals the measured number at the digits printed; low and high end bracket the measured number.
By their numbers in this assay, from the lowest: compounds 1, 2, 3 and 4 (each within the scatter of the next).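

Among these compounds, the pair formed by compound 1 and compound 4 is the first here that differs in one place, and in this assay the exchange of 4-(trifluoromethyl)phenyl for benzyl gives no change at the digits printed from compound 1 to compound 4 (within the scatter). The earlier compounds shown here differed in more than one place, so they could not isolate this position; this pair shows that, on this aromatic carbon, meta to a fused ring and para to a fused ring, a group with fluorine can give way to one without it and leave the read-out unmoved at the digits printed, although this rests on a single exchange. Nothing in the data accounts for this outcome.

Going by these compounds, both groups in this exchange hold a six-membered aromatic ring of carbon only, so it stays open whether an amine, a carboxylic acid or a longer alkyl chain on the same carbon would return the same number in this assay. On these data alone, it also stays open whether the exchange of 4-(trifluoromethyl)phenyl for benzyl would give the same result on a compound carrying the side chain of compound 2 in place of the furan-bearing one.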